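The source may report more compounds than this note shows. Statements on the series, on what has been measured and on what is new or still open speak of the compounds shown alone.

Compound 1, `COc1ccc(NC(=O)C2Cc3cc(OC)c(OC)cc3C2=O)cc1`, and compound 3, `COc1cccc(NC(=O)C2Cc3cc(OC)c(OC)cc3C2=O)c1`, are built on the same core; the difference between the two cores is 3-methoxyphenyl in place of 4-methoxyphenyl on an amide-type nitrogen. In a physicochemical assay for lipophilicity, read by mass spectrometry (on this read-out higher numbers stand for higher lipophilicity and lower numbers for lower lipophilicity), compound 1 gives 2.08, and in this assay compound 3 gives 2.08, so the step is no change at the digits printed from compound 1 to compound 3 (within the scatter). Compound 2, `CCOc1ccc(NC(=O)C2Cc3cc(OC)c(OC)cc3C2=O)cc1`, is derived from compound 1 by a single change, (methyl in place of hydrogen on a saturated chain carbon bound to an oxygen on an aromatic ring). In this assay compound 2 gives 2.42, and the step is a number 0.34 log units higher from compound 1 to compound 2 (beyond the scatter). Compound 4, `CCOc1cccc(NC(=O)C2Cc3cc(OC)c(OC)cc3C2=O)c1`, has not yet been measured in this assay. It stands to compound 3 as compound 2 stands to compound 1: the change is methyl in place of hydrogen on a saturated chain carbon bound to an oxygen on an aromatic ring, made at the same place, on a saturated chain carbon bound to an oxygen on an aromatic ring, so this is the same change seen once already among the measured compounds. Among the measured compounds shown here, on that basis the step from compound 3 to compound 4 is expected to be a number 0.34 log units higher from compound 3 to compound 4 (beyond the scatter), resting on the single earlier instance a number 0.34 log units higher from compound 1 to compound 2 (beyond the scatter) and on the level standing of compound 1 and compound 3, which gives 2.08. Compound 4 is therefore estimated to give about 2.42 in this assay, with a range from 2.15 to 2.7.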

Compound 4, partition coefficient: 2.42
Compound 4: the middle estimate sits on the measured number at the digits printed; measured number inside the range.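

In this assay the change from methoxy to ethoxy gives a number 0.34 log units higher from compound 3 to compound 4 (beyond the scatter) on one core and a number 0.34 log units higher from compound 1 to compound 2 (beyond the scatter) on the other, so the step carried over between these two cores with the same size at the digits printed. Among the compounds shown here, this is only two instances of one change, on cores that differ only as 3-methoxyphenyl differs from 4-methoxyphenyl, and it does not show that the step would hold on a core that differs more, or that any other change would carry over in the same way. No measurement shown here accounts for the agreement between the two steps.

The compounds shown leave open whether the step continues with a longer chain such as propoxy, or what a branched isopropoxy group would give in this assay on either core. They also leave open what an amine or a carboxylic acid on the aromatic ring would give, and whether such a group would behave alike on both cores.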